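Swapping the piperazine phenyl for a tert-butoxycarbonyl

The compounds below may be only part of what the source reports. "The series", "measured", "known", "first", "only" and "open" are said of these compounds alone.

Of the compounds shown here, three sharing one core have been measured in a functional assay on A549 cells (Homo sapiens) for inhibition, read by MTT assay; a higher number here means a weaker inhibitor, a lower number a stronger inhibitor. Compound 1 `O=C(CN1CCN(c2ccccc2F)CC1)Nc1ccc(C(=O)/C=C/c2cn(Cc3ccc(Br)cc3)nn2)cc1` gives 14700 nM. Compound 3 `O=C(CN1CCN(c2ccccc2)CC1)Nc1ccc(C(=O)/C=C/c2cn(Cc3ccc(Br)cc3)nn2)cc1` gives 42100 nM, the second highest number of the three. Compound 2 `CCCCCCCCn1cc(/C=C/C(=O)c2ccc(NC(=O)CN3CCN(C(=O)OC(C)(C)C)CC3)cc2)nn1` gives 43300 nM, which lies within the scatter of compound 3. Going by the values given here, the only single-point step known, a 2.9-fold higher number from compound 1 to compound 3 (0.46 log units; beyond the scatter), concerns a fluoro on an aromatic ring and does not touch the amine nitrogen in the ring. Compound 4 `CC(C)(C)OC(=O)N1CCN(CC(=O)Nc2ccc(C(=O)/C=C/c3cn(Cc4ccc(Br)cc4)nn3)cc2)CC1` differs from compound 3 by tert-butoxycarbonyl in place of phenyl on an amine nitrogen in a ring. Compound 2 carries the same tert-butoxycarbonyl and gives a number close to compound 3, so no step beyond the scatter is expected, a 1.1-fold lower number from compound 3 to compound 4 (0.02 log units; within the scatter). Compound 4 is therefore estimated at 40000 nM, with a range from 15000 nM to 100000 nM.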

Compound 4, half-maximal inhibitory concentration: 38400 nM
Beside the measured number, compound 4's estimate is 1.0-fold (0.02 log units) above it; the measured number falls inside the stated range.
By their numbers in this assay, from the lowest: compound 1; then compounds 4, 3 and 2 (each within the scatter of the next).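

In this assay, tert-butoxycarbonyl in place of phenyl on the amine nitrogen in the ring gives a step within the scatter (a 1.1-fold lower number from compound 3 to compound 4 (0.04 log units; within the scatter)). A second change, 4-bromophenyl in place of heptyl on a saturated chain carbon bound to an aromatic nitrogen, also stays within the scatter (a 1.1-fold lower number from compound 2 to compound 4 (0.05 log units; within the scatter)). At the amine nitrogen, only the 2-fluorophenyl of compound 1 stands apart (a 2.6-fold higher number from compound 1 to compound 4 (0.42 log units; beyond the scatter)). Nothing shown here accounts for these numbers. Open, from the compounds shown here alone, is whether a chlorophenyl, an acetyl or a free amine on that nitrogen would match compound 1 or compound 4.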